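Compound 3 without its nitro group

The source may hold more compounds than are shown below. What is called first, only, known or untested is meant among the compounds shown, and "the series" means these compounds.

Values in a functional assay on A549 cells (Homo sapiens) for antiproliferative activity, read by MTT assay, with a stated time of 72 h; on this read-out lower numbers stand for stronger inhibition and higher numbers for weaker inhibition:
compound 1 `COc1ccccc1-c1ccc2ncn(-c3cc(OC)c(OC)c(OC)c3)c2c1`: 4320 nM
compound 2 `COc1ccc(-c2ccc3ncn(-c4cc(OC)c(OC)c(OC)c4)c3c2)cc1F`: 1430 nM
compound 3 `COc1cc(-n2cnc3ccc(-c4ccc([N+](=O)[O-])cc4)cc32)cc(OC)c1OC`: 8940 nM

Among these three, compound 3 stands highest at 8940 nM, and so is the weakest. Compound 4 `COc1cc(-n2cnc3ccc(-c4ccccc4)cc32)cc(OC)c1OC` has hydrogen in place of nitro on an aromatic carbon, para to a large group: hydrogen in place of nitro on an aromatic carbon. Among the measured compounds shown here, no measured step makes this exact change. The closest evidence comes from the two steps that bring in 4-nitrophenyl: a 2.1-fold higher number from compound 1 to compound 3 (0.32 log units; beyond the scatter) and a 6.3-fold higher number from compound 2 to compound 3 (0.80 log units; beyond the scatter). Both raise the number, while a 3.0-fold lower number from compound 1 to compound 2 (0.48 log units; beyond the scatter) shows that the other two substituents also differ. A modest step to a lower number is therefore expected in this assay. The estimate means a 2.2-fold lower number from compound 3 to compound 4 (0.35 log units; beyond the scatter). For compound 4 the expected value is 4000 nM, with an estimated range of 1600 nM to 10000 nM.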

Compound 4, half-maximal inhibitory concentration: 3060 nM
Beside the measured number, compound 4's estimate is 1.3-fold (0.12 log units) above it; low and high end bracket the measured number.
By their numbers in this assay, from the lowest: compound 2; then compounds 4 and 1 (each within the scatter of the next); then compound 3.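

Taking the nitro group off 4-nitrophenyl shows directly that it costs activity at this place in this assay (a 2.9-fold lower number from compound 3 to compound 4 (0.47 log units; beyond the scatter)). Plain phenyl cannot be told apart from 2-methoxyphenyl (a 1.4-fold lower number from compound 1 to compound 4 (0.15 log units; within the scatter)), whereas 3-fluoro-4-methoxyphenyl retains a real advantage over it (a 2.1-fold higher number from compound 2 to compound 4 (0.33 log units; beyond the scatter)). Nothing available explains these differences.

From the compounds shown here alone, what an amino group or a carboxylic acid would do on this carbon remains open. So does whether the fluorine or the methoxy of compound 2 accounts for its lower number.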